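A few compounds are considered here, and "the series" means these few. Any claim that something is new, unique, unknown or untested is made for them only; others in the source may bear on it.

In a functional assay on THP-1 cells (Homo sapiens) for inhibition, read by ELISA, with stated times of 2 h and 48 h (on this read-out higher numbers stand for weaker inhibition and lower numbers for stronger inhibition), compound 1 `[O-]/[N+](=C\c1cn(-c2ccccc2)nn1)Cc1ccccc1` gives 8000 nM, while compound 2 `COc1ccc(-n2cc(/C=[N+](\[O-])Cc3ccccc3)nn2)cc1` gives 17300 nM, the higher of the two numbers. Compound 3 `COc1ccc(-n2cc(/C=[N+](\[O-])C(C)(C)C)nn2)cc1` differs from compound 2 by tert-butyl in place of benzyl on a double-bonded nitrogen, with tert-butyl in place of benzyl on a double-bonded nitrogen. Among the measured compounds shown here, the only measured step, a 2.2-fold higher number from compound 1 to compound 2 (0.33 log units; beyond the scatter), was modest and comes from methoxy in place of hydrogen on an aromatic carbon, so no measured step covers this exchange. In this assay, going by these compounds, no step beyond the scatter is therefore expected as the central case, and the direction remains open. The estimated change is a 1.2-fold lower number from compound 2 to compound 3 (0.09 log units; within the scatter). For compound 3 the expected value is 14000 nM, with an estimated range of 5000 nM to 40000 nM.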

Compound 3, half-maximal inhibitory concentration: 13500 nM
For compound 3 the middle estimate is 1.0-fold (0.02 log units) above the measured one; low and high end bracket the measured number.
By their numbers in this assay, from the lowest: compounds 1, 3 and 2 (each within the scatter of the next, the first and the last beyond it).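

Among the compounds shown here, on the double-bonded nitrogen, tert-butyl in place of benzyl gives a 1.3-fold lower number from compound 2 to compound 3 (0.11 log units; within the scatter) in this assay and is the first exchange at this position. With the methoxy group in place, the read-out at this position therefore does not depend on the six-membered aromatic ring of benzyl, as a group with no ring stands within the scatter of it. Nothing available explains this outcome.

Going by these compounds, whether tert-butyl behaves the same way on the core of compound 1, without methoxy, remains open. So does the outcome at this nitrogen of a longer chain carrying an amine or a carboxylic acid.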